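One side-chain change carried over to a second core

The source may hold more compounds than are shown below. What is called first, only, known or untested is meant among the compounds shown, and "the series" means these compounds.

Compound 1 `COc1ccc(C(=O)c2ccc(OC)c3c2C=CC(C)(C)O3)c(NC(=O)CO)c1`: 940 nM
Compound 2 `CNCC(=O)Nc1cc(OC)ccc1C(=O)c1ccc(OC)c2c1C=CC(C)(C)O2`: 3040 nM
Compound 3 `COc1ccc(C(=O)c2cc(OC)c(OC)c(OC)c2)c(NC(=O)CO)c1`: 230 nM

All three were tested in a functional assay on MCF7 cells (Homo sapiens) for antiproliferative activity, read by MTT assay, with a stated time of 48 h; on this read-out lower numbers stand for stronger inhibition and higher numbers for weaker inhibition. Compound 1 gives 940 nM and compound 2 gives 3040 nM. The two share one core and differ only by methylamino in place of hydroxy on a saturated chain carbon bound to a carbonyl carbon. That change made a 3.2-fold higher number from compound 1 to compound 2 (0.51 log units; beyond the scatter), so the number rose and the inhibition weakened. Compound 3, with 230 nM, has the lowest number of the three; how its core differs from the core of compound 1 is not broken down here.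

Compound 4 `CNCC(=O)Nc1cc(OC)ccc1C(=O)c1cc(OC)c(OC)c(OC)c1` has not yet been measured. Among the measured compounds shown here, it is built from compound 3 by methylamino in place of hydroxy on a saturated chain carbon bound to a carbonyl carbon, the same change at the same place as the one from compound 1 to compound 2. Because the earlier step was a 3.2-fold higher number from compound 1 to compound 2 (0.51 log units; beyond the scatter), a step of similar size is expected here, though the cores differ, so the range is kept wide. For compound 4 the expected step is a 3.0-fold higher number from compound 3 to compound 4 (0.48 log units; beyond the scatter). Compound 4 is therefore estimated at 700 nM, most likely between 300 nM and 1800 nM.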

Compound 4, half-maximal inhibitory concentration: 550 nM
Beside the measured number, compound 4's estimate is 1.3-fold (0.10 log units) above it; low and high end bracket the measured number.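

In this assay, putting methylamino in place of hydroxy on the core of compound 3 gave a 2.4-fold higher number from compound 3 to compound 4 (0.38 log units; beyond the scatter), so the number rose and the inhibition weakened, as it did on the core of compound 1. The change therefore carried over from one core to the other in both direction and size, with the two steps no further apart than repeated measurements of this kind would be expected to scatter: the same change on two cores in this assay, a 3.2-fold higher number (0.51 log units; beyond the scatter) from compound 1 to compound 2 and a 2.4-fold higher number (0.38 log units; beyond the scatter) from compound 3 to compound 4, 1.4-fold (0.13 log units) apart, within the scatter of two such steps

Among the compounds shown here, this rests on only two pairs of compounds in one cell assay, so it does not show that the step would hold on any further core, nor does it explain why the number rises. The compounds shown leave open what other groups on the same saturated chain carbon bound to a carbonyl carbon would do, such as a primary amine, a dimethylamino group or a carboxylic acid. They also leave open whether a longer chain carrying the methylamino group would give a step of similar size.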